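The compounds below may be only part of what the source reports. "The series", "measured", "known", "first", "only" and "open" are said of these compounds alone.

Notes on the series. Compound 3 `CC(C)(C)C(=O)N1CCC[C@H]1C(=O)N1CCC(NS(=O)(=O)c2cc(S(=O)(=O)c3ccccc3)ccc2C(F)(F)F)CC1` gives 40 nM in an assay on isolated protein for binding affinity to secreted frizzled-related protein 1 (Homo sapiens), read by fluorescence (a higher number here means a weaker inhibitor, a lower number a stronger inhibitor), the lowest number among the three compounds measured. Compound 1 `CC(C)(C)OC(=O)N1CCC[C@@H]1C(=O)N1CCC(NS(=O)(=O)c2cc(S(=O)(=O)c3ccccc3)ccc2C(F)(F)F)CC1` gives 120 nM and compound 2 `CC(C)(C)OC(=O)N1C(=O)CC[C@H]1C(=O)N1CCC(NS(=O)(=O)c2cc(S(=O)(=O)c3ccccc3)ccc2C(F)(F)F)CC1` gives 130 nM; both values stand above that of compound 3 by more than the usual scatter, so compound 3 is the strongest binder on the numbers seen so far. Within the data shown here, the one step that isolates the substituent on the ring nitrogen is a 3.0-fold lower number from compound 1 to compound 3 (0.48 log units; beyond the scatter).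

Compound 4 `CN1CCC[C@H]1C(=O)N1CCC(NS(=O)(=O)c2cc(S(=O)(=O)c3ccccc3)ccc2C(F)(F)F)CC1` carries the change (methyl in place of (tert-butyl)carbonyl on an amine nitrogen in a ring). Among the measured compounds shown here, no measured pair shows the carbonyl on that nitrogen being removed altogether; the step from compound 1 to compound 3 only swaps one carbonyl-bearing group for another and shifts the number modestly. The expectation is therefore a modest loss for compound 4 relative to compound 3, with a wide range because the data do not cover this kind of change, a step estimated as a 2.8-fold higher number from compound 3 to compound 4 (0.44 log units; beyond the scatter). Compound 4 is expected to give about 110 nM, between 30 nM and 400 nM.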

Compound 4, half-maximal inhibitory concentration: 120 nM
The estimate for compound 4 lay 1.1-fold (0.04 log units) below the measured number, within the range that was stated.
By their numbers in this assay, from the lowest: compound 3; then compounds 1, 4 and 2 (each within the scatter of the next).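

Removing the (tert-butyl)carbonyl group from the amine nitrogen in the ring gives a 3.0-fold higher number from compound 3 to compound 4 (0.48 log units; beyond the scatter) in this assay, so this position responds when that group gives way to methyl. The step with no change at the digits printed from compound 1 to compound 4 (within the scatter) shows that methyl and the 1-(tert-butoxycarbonyl) substituent cannot be told apart here, and a carbonyl on this nitrogen is thus not needed to reach the level of compound 1; among the compounds sharing this pyrrolidine, only the (tert-butyl)carbonyl of compound 3 stands apart. No measurement at hand accounts for either step.

Compound 4 loses the carbonyl and the tert-butyl together, so the two parts remain unseparated; an acetyl group or a neopentyl chain on the same nitrogen would divide them. From the compounds shown here alone, how a plain hydrogen, an ethyl or a benzyl group on that nitrogen would compare also stays open.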